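Purine series with chloromethylbenzyl groups: dropping the amino group

The compounds below may be only part of what the source reports. "The series", "measured", "known", "first", "only" and "open" are said of these compounds alone.

Three compounds in this set have numbers in a functional assay on KM12 cells (Homo sapiens) for cytotoxicity, read by sulforhodamine B assay, with a stated time of 48 h; on this read-out higher numbers stand for weaker inhibition of growth and lower numbers for stronger inhibition of growth. Compound 1 `Nc1nc(Cl)c2ncn(Cc3ccccc3CCl)c2n1` gives 15500 nM in this assay, and this is the highest of the three numbers, that is, the weakest inhibition of growth seen so far. Compound 2 `ClCc1ccc(Cn2cnc3c(Cl)nc(Cl)nc32)cc1` gives 1820 nM, and compound 3 `ClCc1ccccc1Cn1cnc2ncnc(Cl)c21` gives 3630 nM; both of these lie beyond the scatter from the number for compound 1, with compound 2 the furthest away and compound 3 the nearest. Going by the values given here, no two measured compounds differ in a single place, so no clean step has been measured.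

Compound 4 `ClCc1ccccc1Cn1cnc2c(Cl)ncnc21` has not yet been measured in this assay. It is related to compound 1 by a single change: hydrogen in place of amino on an aromatic carbon. The two compounds that lack an amino group, compound 2 and compound 3, both give lower numbers than compound 1, though each also differs from compound 1 elsewhere, so this is only a loose pointer. On that basis a step toward a lower number is expected, of moderate size, with a 3.1-fold lower number from compound 1 to compound 4 (0.49 log units; beyond the scatter) as the estimated step, and considerable uncertainty because of the numbers of compound 2 at 1820 nM and compound 3 at 3630 nM. The number for compound 4 is estimated at 5000 nM, with an expected range from 1500 nM to 16000 nM.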

Compound 4, concentration for 50% growth inhibition: 16600 nM
The estimate for compound 4 lay 3.3-fold (0.52 log units) below the measured number, and the stated range ends below it.
By their numbers in this assay, from the lowest: compounds 2 and 3 (each within the scatter of the next); then compounds 1 and 4 (each within the scatter of the next).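

In this assay, hydrogen in place of amino on this aromatic carbon gives a 1.1-fold higher number from compound 1 to compound 4 (0.03 log units; within the scatter), so in this pair the amino group, with the hydrogen-bond donor and acceptor counted for it, can leave this position without a step beyond the scatter. The lower numbers of compound 2 and compound 3 therefore cannot be credited to the missing amino group, since this single change does not reproduce them and each of those compounds also differs from compound 1 elsewhere. No measurement is available that would explain why this step is flat.

The compounds shown leave open whether a group other than amino or hydrogen on the same carbon, such as a methoxy group or a methylamino group, would move the number in this assay. They also leave open whether the same exchange would stay within the scatter on the cores of compound 2 and compound 3, for which no single-change partner is shown.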